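Trading the acetylpiperidine for an aromatic ring

A few compounds are considered here, and "the series" means these few. Any claim that something is new, unique, unknown or untested is made for them only; others in the source may bear on it.

In a physicochemical assay for solubility, read by nephelometry, at pH 7.4 (on this read-out lower numbers stand for lower solubility and higher numbers for higher solubility), compound 2 `COc1cccc(NC(=O)c2nnn(CC3CCN(C(C)=O)CC3)c2N)c1` gives > 250000 nM, which is a limit and not a number. Compound 1 `COc1cccc(NC(=O)c2nnn(Cc3ccncc3)c2N)c1` gives < 12000 nM, also a limit. Going by the values given here, the only measured step, an at least 20-fold higher number from compound 1 to compound 2 (1.31 log units; beyond the scatter), was large and beyond the scatter, and it put 1-acetylpiperidin-4-yl in place of pyridin-4-yl. Compound 3 `COc1cccc(NC(=O)c2nnn(Cc3ccc([S+](C)[O-])cc3)c2N)c1` returns to an aromatic ring: a group of 9 heavy atoms (7 carbon, 1 oxygen, 1 sulfur; one six-membered aromatic ring of carbon only) in place of a group of 9 heavy atoms (7 carbon, 1 nitrogen, 1 oxygen; one six-membered non-aromatic ring with 1 hetero atom), on a saturated chain carbon bound to an aromatic nitrogen. That ring is not pyridin-4-yl, so the earlier step of an at least 20-fold higher number from compound 1 to compound 2 (1.31 log units; beyond the scatter) is only a rough guide, pointing to a clear fall in the opposite direction. The expected change is an at least 5.0-fold lower number from compound 2 to compound 3 (0.69 log units; beyond the scatter). For compound 3 the estimated value is 50000 nM, with a range of 12000 nM to 200000 nM.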

Compound 3, solubility: > 250000 nM
Compound 3 ended at the assay's limit (the forecaster's own chance of this, stated with the estimate: 25%); middle value at least 5.0-fold (0.69 log units) from the limit.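

At this position, an aromatic ring does not by itself go with a low reading in this assay: a group with a six-membered aromatic ring of carbon only, in place of pyridin-4-yl, gives an at least 20-fold higher number from compound 1 to compound 3 (1.31 log units; beyond the scatter). Compound 3 gives > 250000 nM, which is a limit, and the step from compound 2 to compound 3 cannot be read. This limit is shared: the limit of > 250000 nM in this assay, at which 2 of the 3 values shown sit.

On these data alone, how far apart compound 2 and compound 3 truly lie stays open. So does the reading with a carboxylic acid or an amine on the aromatic ring.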